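This account rests on a few compounds, and the source may have more. Where it says the series, first, only, none or still open, it means among the compounds named here.

Measured so far in the series:

compound 1, `COc1ccc(-c2cc3cc(C)ccc3c(N3CCN(C)CC3)n2)cc1`: 3710 nM
compound 2, `Cc1ccc2c(N3CCN(C)CC3)nc(-c3ccc(Cl)cc3)cc2c1`: 2400 nM
compound 3, `CN1CCN(c2nc(-c3ccc(Cl)cc3)cc3c(N(C)C)cccc23)CC1`: 4300 nM

All three values come from a functional assay on SK-MEL-2 cells (Homo sapiens) for cytotoxicity; a lower number here means a stronger inhibitor, a higher number a weaker inhibitor. Compound 1 differs from compound 2 in one place: methoxy in place of chloro on an aromatic carbon. The resulting step was a 1.5-fold higher number from compound 2 to compound 1 (0.19 log units; within the scatter), so the exchange left the cytotoxicity essentially unchanged in that pair. Compound 3 carries a different core; the difference between the two cores is not broken down here, and the values of compound 3 and compound 2 lie within the usual scatter of each other, so no order is read from them.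

Compound 4, `COc1ccc(-c2cc3c(N(C)C)cccc3c(N3CCN(C)CC3)n2)cc1`, is not yet measured. It differs from compound 3 by methoxy in place of chloro on an aromatic carbon. This is the same change as that from compound 2 to compound 1, at a place described in the same words. On the evidence of that single earlier step, a step of a 1.4-fold higher number from compound 3 to compound 4 (0.14 log units; within the scatter) is expected in this assay, that is, a number close to that of compound 3 and within the usual scatter. Compound 4 is therefore estimated at 6000 nM, with a likely range from 2800 nM to 13000 nM.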

Compound 4, half-maximal inhibitory concentration: 3980 nM
Estimate against measurement, compound 4: 1.5-fold (0.18 log units) above, and the stated range covers the measured number.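

In this assay, exchanging 4-chlorophenyl for 4-methoxyphenyl on the core of compound 3 gives a 1.1-fold lower number from compound 3 to compound 4 (0.03 log units; within the scatter). Set beside the earlier step, the change reads alike on both cores: the same change on two cores in this assay, a 1.5-fold higher number (0.19 log units; within the scatter) from compound 2 to compound 1 and a 1.1-fold lower number (0.03 log units; within the scatter) from compound 3 to compound 4, 1.7-fold (0.22 log units) apart, within the scatter of two such steps. This shows that the exchange left the cytotoxicity number essentially unchanged on these two cores, but with both steps inside the scatter, it does not show a real effect of the change that carries over, and two pairs say nothing about any other core.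

Only chloro and methoxy stand on this aromatic carbon in the compounds shown. Going by these compounds, whether an amine, a carboxylic acid or a longer chain at the same place would move the number beyond the scatter, on either core, remains open.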